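A few compounds are considered here, and "the series" means these few. Any claim that something is new, unique, unknown or untested is made for them only; others in the source may bear on it.

Compound 1 `CNc1ccc(C(=O)C[C@@H](O)[C@H](C)C[C@@H](C)[C@H](O)[C@H](C)/C=C/C=C/C=C/[C@H](O)CC(=O)O)cc1` carries a methylamino group on its aromatic ring. In a functional assay on MDA-MB-231 cells (Homo sapiens) for cytotoxicity, read by sulforhodamine B assay, with a stated time of 72 h (on this read-out lower numbers stand for stronger inhibition and higher numbers for weaker inhibition), compound 1 gives only a limit, > 10000 nM. Among the compounds with values here, compound 2 `CC(=O)Nc1ccc([C@H](O)C[C@@H](O)[C@H](C)C[C@@H](C)[C@H](O)[C@H](C)/C=C/C=C/C=C/[C@H](O)CC(=O)O)cc1` is its single measured neighbour that differs in one place. In this assay compound 2 likewise gives only a limit, > 10000 nM. The step that the two limits leave unreadable from compound 1 to compound 2 cannot be read because of the limit of > 10000 nM in this assay, at which 2 of the 2 values shown sit. Compound 3 `C[C@H](/C=C/C=C/C=C/[C@H](O)CC(=O)O)[C@@H](O)[C@H](C)C[C@@H](C)[C@H](O)CC(=O)c1ccc(N[C@@H]2O[C@H](CO)[C@@H](O)[C@H](O)[C@H]2O)cc1` arises from compound 1 through (3,4,5-trihydroxy-6-(hydroxymethyl)oxan-2-yl in place of methyl on a nitrogen on an aromatic ring). No measured step bears on this change; the only measured step, from compound 1 to compound 2, is unreadable, and compound 1 itself stands at the limit, so the numbers shown set no direction. Compound 3 is therefore expected to give 10000 nM, within 4000 nM and 30000 nM. The step that this estimate means, a number no higher from compound 1 to compound 3 (the limit leaves the size open), is expected to be none beyond the scatter, with compound 3 most likely again reported only as a limit in this assay.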

Compound 3, half-maximal inhibitory concentration: > 10000 nM
Compound 3: no number, only a limit; the forecaster's own chance of this, stated with the estimate: 80%; the middle value sits exactly at the limit.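

Compound 3, like compound 1, is reported in this assay only as a limit, so the step between them cannot be read: the limit of > 10000 nM in this assay, at which 3 of the 3 values shown sit.

The compounds shown leave open whether swapping methyl for 3,4,5-trihydroxy-6-(hydroxymethyl)oxan-2-yl on that nitrogen changes the read-out at all, and what actual number any of the three compounds would give in this assay.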